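A few compounds are considered here, and "the series" means these few. Any claim that something is new, unique, unknown or untested is made for them only; others in the source may bear on it.

Measured compounds:
compound 1, `COc1cc2c(cc1OC)C(CC(=O)N(C)C)CC2`: 35.9%
compound 2, `CCNC(=O)CC1CCc2cc(OC)c(OC)cc21`: 26.6%
compound 3, `CCCNC(=O)CC1CCc2cc(OC)c(OC)cc21`: 26.6%

In a functional assay on the whole organism (strain Wistar) for inhibition, with Rattus norvegicus as the target, read by paw edema, with stated times of 60 min and 4 h, at a dose of 100 mg/kg by the oral route (on this read-out higher numbers stand for more inhibition at the one dose given (going by the name of the read-out) and lower numbers for less inhibition), compound 3 gives 26.6%, the same number as compound 2 and with it the lowest of the three; the step of a number 9.3 percentage points lower from compound 1 to compound 3 (within the scatter) stays within the scatter. Compound 4, `CCCCNC(=O)CC1CCc2cc(OC)c(OC)cc21`, differs from compound 3 by methyl in place of hydrogen on a saturated chain carbon, three bonds along the chain from an amide-type nitrogen. The step that bears most directly on this is no change at the digits printed from compound 2 to compound 3 (within the scatter), where the chain on the amide nitrogen also grew by one methyl. The steps of a number 9.3 percentage points lower from compound 1 to compound 2 (within the scatter) and a number 9.3 percentage points lower from compound 1 to compound 3 (within the scatter) likewise reshaped the amide substituent without moving the number beyond the scatter. No change beyond the scatter is therefore expected in this assay. The expected step is a number 0.6 percentage points lower from compound 3 to compound 4 (within the scatter). Compound 4 is estimated to give 26%, within 12% to 40%.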

Compound 4, a percentage reported as inhibition, in the whole organism at one dose (the size of the read-out at that dose, not a potency): 25%
Compound 4: the middle estimate sits 1 percentage points above what was measured; the range from low to high includes it.
By their numbers in this assay, from the lowest: compounds 4, 2, 3 and 1 (each within the scatter of the next, the first and the last beyond it).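

In this assay the butyl chain on the amide nitrogen gives a number 1.6 percentage points lower from compound 3 to compound 4 (within the scatter) and a number 1.6 percentage points lower from compound 2 to compound 4 (within the scatter) so ethyl, propyl and butyl cannot be told apart at this position. Butylamino in place of dimethylamino gives a number 10.9 percentage points lower from compound 1 to compound 4 (beyond the scatter) as the first step in the series beyond the scatter, though only a modest one, while compound 2 and compound 3 each remain within the scatter of compound 1. Nothing measured here gives a reason for this. Still open, as far as these compounds go, is what a longer chain such as hexyl would do at this position. Also open, from the compounds shown here alone, is what a chain ending in an amine or a carboxylic acid would do.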